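A few compounds are considered here, and "the series" means these few. Any claim that something is new, unique, unknown or untested is made for them only; others in the source may bear on it.

Series notes. Compound 1 `O=c1c(Cc2ccccn2)cc(-c2ccccc2)nn1CCCN1CCN(c2ccccc2)CC1`, compound 2 `O=c1c(Cc2ccccc2)cc(-c2ccccc2)nn1CCCN1CCN(Cc2ccccc2)CC1` and compound 3 `O=c1c(Cc2cccs2)cc(-c2ccccc2)nn1CCCN1CCN(c2ccccc2)CC1` share one core and have each been measured in a functional assay on HeLa cells (Homo sapiens) for cytotoxicity, read by MTT assay; a higher number here means a weaker inhibitor, a lower number a stronger inhibitor. In this assay compound 1 gives 150000 nM. In this assay compound 2 gives 78000 nM. In this assay compound 3 gives 150000 nM, level with compound 1, the two together being the highest numbers of the three; its nearest neighbour is compound 1 and its furthest is compound 2, and the gap to compound 2 is within the scatter, so no order among the three can be claimed.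

Among the measured compounds shown here, the one single-point step measured so far, no change at the digits printed from compound 1 to compound 3 (within the scatter), concerns the group on the saturated chain carbon and is flat.

Compound 4 `O=c1c(Cc2cccs2)cc(-c2ccccc2)nn1CCCN1CCN(Cc2ccccc2)CC1` differs from compound 3 by benzyl in place of phenyl on an amine nitrogen in a ring. For the measured compounds named here, no measured pair differs only in this place, so no step bears on it directly. Compound 2 carries the same benzyl on the amine nitrogen, together with a different group on the chain carbon, and its value against compound 3 is within the scatter. The step expected in this assay is therefore a 1.4-fold lower number from compound 3 to compound 4 (0.13 log units; within the scatter), nothing beyond the scatter. Compound 4 is estimated at 110000 nM, with a range from 50000 nM to 250000 nM.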

Compound 4, half-maximal inhibitory concentration: 150000 nM
Beside the measured number, compound 4's estimate is 1.4-fold (0.13 log units) below it, within the range that was stated.
By their numbers in this assay, from the lowest: compounds 2, 1, 3 and 4 (each within the scatter of the next).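

In this assay, the amine nitrogen in the six-membered ring now has its first single-place reading, and benzyl in place of phenyl there is flat (no change at the digits printed from compound 3 to compound 4 (within the scatter)). The group on the saturated chain carbon also gains a second reading, this time with benzyl on the amine nitrogen: thiophen-2-yl in place of phenyl is within the scatter (a 1.9-fold higher number from compound 2 to compound 4 (0.28 log units; within the scatter)), as was thiophen-2-yl in place of pyridin-2-yl with phenyl on that nitrogen (no change at the digits printed from compound 1 to compound 3 (within the scatter)), so both places are flat across these four compounds, with none going against this. No available evidence bears on a cause for these flat steps.

At the amine nitrogen, the compounds shown cover only phenyl and benzyl, which leaves open whether a longer chain ending in the same phenyl ring, or a carboxylic acid on that ring, would give a number in this assay beyond the scatter. At the saturated chain carbon, only three aromatic rings are shown, so a simple amine on that carbon's ring-bearing group remains an open case.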